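Swapping one five-membered ring for another

The source may hold more compounds than are shown below. What is called first, only, known or untested is meant among the compounds shown, and "the series" means these compounds.

In an ADME assay on HEp-2 cells (Homo sapiens) for cytotoxicity (on this read-out higher numbers stand for lower toxicity in this test and lower numbers for higher toxicity in this test), three compounds that share one core and differ in a single group give clear numbers. Compound 1 (`CC(C)CCn1c(Cn2c(=O)n(C(C)C)c3ccccc32)nc2cc(CF)ccc21`) gives 37300 nM and compound 2 (`CC(C)CCn1c(Cn2c(=O)n(C(C)C)c3ccccc32)nc2cc(Br)ccc21`) gives 18100 nM while compound 3 (`CC(C)CCn1c(Cn2c(=O)n(C(C)C)c3ccccc32)nc2cc(-c3ncon3)ccc21`) gives 223000 nM as the highest of the three. Compound 4 (`CC(C)CCn1c(Cn2c(=O)n(C(C)C)c3ccccc32)nc2cc(-c3nn[nH]n3)ccc21`) is still unmeasured and carries 2H-tetrazol-5-yl in place of 1,2,4-oxadiazol-3-yl on an aromatic carbon.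

Two measured steps lead to the oxadiazole: a 6.0-fold higher number from compound 1 to compound 3 (0.78 log units; beyond the scatter) is modest and a 12-fold higher number from compound 2 to compound 3 (1.09 log units; beyond the scatter) is large. The remaining step, a 2.1-fold lower number from compound 1 to compound 2 (0.31 log units; beyond the scatter), is modest and involves no ring at all. In those larger steps the group changed kind, whereas here one five-membered aromatic ring replaces another. Among the measured compounds shown here, no measured compound carries the tetrazole, so this is only a cautious guess. A small change is expected, slightly downward and likely within the scatter, as a 1.2-fold lower number from compound 3 to compound 4 (0.09 log units; within the scatter) indicates. Compound 4 is estimated at 180000 nM (expected range 70000 nM to 400000 nM).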

Compound 4, half-maximal cytotoxic concentration: 2000 nM
Compound 4: the middle estimate sits 90-fold (1.95 log units) above what was measured; the measured number lies below the stated range.
By their numbers in this assay, from the lowest: compound 4; then compound 2; then compound 1; then compound 3.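

In this assay, sharing a ring size and aromatic character does not keep the number steady at this position: a 110-fold lower number from compound 3 to compound 4 (2.05 log units; beyond the scatter) is the largest step in the series, although both groups are five-membered aromatic rings with 5 heavy atoms. The tetrazole also falls below the two non-ring groups, with a 9.1-fold lower number from compound 2 to compound 4 (0.96 log units; beyond the scatter) and a 19-fold lower number from compound 1 to compound 4 (1.27 log units; beyond the scatter) as the two further steps, so the two ring groups give the highest and lowest numbers of the four. The counted differences are that 2H-tetrazol-5-yl has 4 nitrogen atoms and 1 hydrogen-bond donor, while 1,2,4-oxadiazol-3-yl has 2 nitrogen atoms, 1 oxygen atom and 0 hydrogen-bond donors.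

Among the compounds shown here, no available data explain why this swap moves the number so far. From the compounds shown here alone, a tetrazole with a methyl group replacing its ring hydrogen, or a carboxylic acid at this position, remains open.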